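This account rests on a few compounds, and the source may have more. Where it says the series, first, only, none or still open, it means among the compounds named here.

Measured so far, in a functional assay on cells (Neutrophil, Homo sapiens) for inhibition, with a stated time of 10 min; a lower number here means a stronger inhibitor, a higher number a weaker inhibitor:

compound 1, `CCOC(=O)c1cnn2c1N(C(=O)Nc1cccc(F)c1)C(c1ccccc1)C2`: 9.2 nM
compound 2, `CCOC(=O)c1cnn2c1N(C(=O)Nc1ccc(F)cc1)C(c1ccccc1)C2`: 10.3 nM
compound 3, `NC(=O)c1cnn2c1N(C(=O)Nc1cccc(F)c1)C(c1ccccc1)C2`: 3.9 nM

Compound 1 and compound 2 share one core and differ only in the aryl group on the urea nitrogen: 4-fluorophenyl in place of 3-fluorophenyl on an amide-type nitrogen. This change occurs twice among the compounds considered here. Between the two measured examples it made a 1.1-fold higher number from compound 1 to compound 2 (0.05 log units; within the scatter), so the two values sit in the same band and no order can be read from them.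

Compound 1 and compound 3 differ in the group on the carbonyl carbon attached to the core: amino in place of ethoxy on a carbonyl carbon. That change gave a 2.4-fold lower number from compound 1 to compound 3 (0.37 log units; beyond the scatter). Compound 3 therefore shows the lowest number of the three in this assay, and its steps to compound 1 and to compound 2 are both beyond the scatter.

Compound 4, `NC(=O)c1cnn2c1N(C(=O)Nc1ccc(F)cc1)C(c1ccccc1)C2`, has not yet been measured. It differs from compound 3 by 4-fluorophenyl in place of 3-fluorophenyl on an amide-type nitrogen. The place of this change is described in the same words for the pair compound 1 to compound 2 and for the pair compound 3 to compound 4, so it is the same change, repeated on the core of compound 3 instead of the core of compound 1.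

The expected step is a 1.1-fold higher number from compound 3 to compound 4 (0.04 log units; within the scatter); this rests on the earlier instance of the same change, where compound 1 to compound 2 gave a 1.1-fold higher number from compound 1 to compound 2 (0.05 log units; within the scatter), a step within the scatter. Compound 4 is therefore expected to give about 4.3 nM in this assay, estimated to lie between 2.2 nM and 8.5 nM.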

Compound 4, half-maximal inhibitory concentration: 11.4 nM
Beside the measured number, compound 4's estimate is 2.7-fold (0.42 log units) below it; the whole stated range lies below it.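

In this assay, 4-fluorophenyl in place of 3-fluorophenyl on an amide-type nitrogen gave a 2.9-fold higher number from compound 3 to compound 4 (0.47 log units; beyond the scatter), and amino in place of ethoxy on a carbonyl carbon gave a 1.1-fold higher number from compound 2 to compound 4 (0.04 log units; within the scatter). Taken alone, the first change looks larger on the core of compound 3 than on the core of compound 1, but the two instances cannot be separated, so the data show neither a dependence on the core nor a reliable carry-over from one core to the other: the same change on two cores in this assay, a 1.1-fold higher number (0.05 log units; within the scatter) from compound 1 to compound 2 and a 2.9-fold higher number (0.47 log units; beyond the scatter) from compound 3 to compound 4, 2.6-fold (0.42 log units) apart, within the scatter of two such steps. The same holds for amino in place of ethoxy, whose step lies beyond the scatter with 3-fluorophenyl and within it with 4-fluorophenyl, and with one pair for each aryl group, any interplay between the two places remains unproven: the same change on two cores in this assay, a 2.4-fold lower number (0.37 log units; beyond the scatter) from compound 1 to compound 3 and a 1.1-fold higher number (0.04 log units; within the scatter) from compound 2 to compound 4, 2.6-fold (0.42 log units) apart, within the scatter of two such steps.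

The compounds shown leave open how other groups on the carbonyl carbon, such as a methylamino group or a hydroxyl group giving the carboxylic acid, would fit these steps. They also leave open whether an unsubstituted phenyl or a chlorophenyl on the amide-type nitrogen would follow the two fluorophenyl groups.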